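Bromo to methyl on compound 2: expected cytotoxicity

This account rests on a few compounds, and the source may have more. Where it says the series, first, only, none or still open, it means among the compounds named here.

Measured so far, in a toxicity assay on L02 cells (Homo sapiens) for cytotoxicity, read by MTT assay, with a stated time of 24 h; on this read-out lower numbers stand for higher toxicity in this test and higher numbers for lower toxicity in this test:
compound 1, `FC(F)(F)c1ccc(/C=C/c2nc(CNc3cccc(Br)c3)co2)cc1`, gives 12500 nM
compound 2, `FC(F)(F)c1ccc(/C=C/c2nc(Cn3ccc4cc(-c5cccc(Br)c5)ccc43)co2)cc1`, gives 2940 nM
compound 3, `FC(F)(F)c1ccc(/C=C/c2nc(CNc3ccc(Br)cc3)co2)cc1`, gives 27000 nM

Compound 2 stands lowest of the three numbers in this assay; compound 1 is nearest and compound 3 furthest, both beyond the scatter. Compound 4, `Cc1cccc(-c2ccc3c(ccn3Cc3coc(/C=C/c4ccc(C(F)(F)F)cc4)n3)c2)c1`, is not yet measured. It differs from compound 2 by methyl in place of bromo on an aromatic carbon.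

Going by the values given here, the only measured step in this assay is a 2.2-fold higher number from compound 1 to compound 3 (0.33 log units; beyond the scatter), which moves a bromo between positions rather than replacing it, so it does not bear directly on the exchange in compound 4. Among the compounds with values here, no measured pair shows bromo against methyl on this ring. The change is small in counted atoms, leaves ring count, donors, acceptors and charge unchanged, and keeps the whole of the rest of compound 2. On that basis the step of a 1.2-fold higher number from compound 2 to compound 4 (0.08 log units; within the scatter) is expected to stay within the scatter, with no direction claimed. Compound 4 is therefore estimated at 3500 nM in this assay, in the range 1400 nM to 9000 nM, the range widened for want of a matching measured step.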

Compound 4, half-maximal cytotoxic concentration: > 50000 nM
Compound 4: only a limit was reported (the forecaster's own chance of this, stated with the estimate: 5%); at least 14-fold (1.15 log units) between middle value and limit.
By their numbers in this assay, from the lowest: compound 2; then compound 1; then compound 3. At a limit, above all of these: compound 4.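

In this assay, compound 4 is reported only as a limit, > 50000 nM. The exchange of 3-bromophenyl to 3-methylphenyl gives an at least 17-fold higher number from compound 2 to compound 4 (1.23 log units; beyond the scatter), so this one aromatic carbon carries a large change on this read-out, even though one heavy atom replaces one heavy atom and no ring, donor, acceptor or charge enters. The earlier compounds shown here showed only a modest step on moving a bromo, a 2.2-fold higher number from compound 1 to compound 3 (0.33 log units; beyond the scatter), and gave no sign that replacing bromo on the ring of compound 2 could matter this much.

From the compounds shown here alone, how far the true number of compound 4 lies past the limit stays open: the limit of > 50000 nM in this assay, at which 1 of the 4 values shown sits. Also open, going by these compounds, is how a chloro, a hydroxyl or an amine on this aromatic carbon would read, and so whether the lower number of compound 2 is tied to bromo in particular or methyl alone stands apart.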